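The source may hold more compounds than are shown below. What is called first, only, known or untested is meant among the compounds shown, and "the series" means these compounds.

Compound 1 `Cn1ncc(Cl)c1-c1cc(C(=O)N[C@@H]2CN[C@H](CC(O)CO)C[C@H]2c2ccc(Cl)c(Cl)c2)oc1Cl` carries a 1,2-dihydroxyethyl group on a saturated chain carbon bound to a saturated ring carbon. In a functional assay on LNCaP cells (Homo sapiens) for antiproliferative activity (on this read-out higher numbers stand for weaker inhibition and lower numbers for stronger inhibition), compound 1 gives 70 nM, the lowest number among the three measured compounds. Compound 2 `Cn1ncc(Cl)c1-c1cc(C(=O)N[C@@H]2CN[C@H](CCN3CCC(O)CC3)C[C@H]2c2ccc(Cl)c(Cl)c2)oc1Cl` gives 1140 nM and compound 3 `Cn1ncc(Cl)c1-c1cc(C(=O)N[C@@H]2CN[C@H](CCN3CCCC3)C[C@H]2c2ccc(Cl)c(Cl)c2)oc1Cl` gives 1920 nM. The steps from compound 1 are a 16-fold higher number from compound 1 to compound 2 (1.21 log units; beyond the scatter) and a 27-fold higher number from compound 1 to compound 3 (1.44 log units; beyond the scatter), while between the two amines a 1.7-fold higher number from compound 2 to compound 3 (0.23 log units; within the scatter). Compound 4 `Cn1ncc(Cl)c1-c1cc(C(=O)N[C@@H]2CN[C@H](CC(=O)NCCO)C[C@H]2c2ccc(Cl)c(Cl)c2)oc1Cl` is not yet measured; it differs from compound 1 by (2-hydroxyethyl)carbamoyl in place of 1,2-dihydroxyethyl on a saturated chain carbon bound to a saturated ring carbon. The two measured steps both replace the diol with a (4-hydroxypiperidin-1-yl)methyl or a (pyrrolidin-1-yl)methyl group, each with a ring, whereas the group entering in compound 4 has no ring and keeps the same count of hydrogen-bond donors and acceptors, so those steps bear on this one only loosely. A small step is therefore expected, a 1.7-fold higher number from compound 1 to compound 4 (0.23 log units; within the scatter), leaning toward a somewhat higher number. Compound 4 is estimated at 120 nM, with a range from 40 nM to 400 nM.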

Compound 4, half-maximal inhibitory concentration: 40 nM
Beside the measured number, compound 4's estimate is 3.0-fold (0.48 log units) above it; the range from low to high includes it.
By their numbers in this assay, from the lowest: compounds 4 and 1 (each within the scatter of the next); then compounds 2 and 3 (each within the scatter of the next).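

In this assay, the (2-hydroxyethyl)carbamoyl group takes the place of 1,2-dihydroxyethyl with a 1.8-fold lower number from compound 1 to compound 4 (0.24 log units; within the scatter), so this position accepts an amide chain with a higher heavy-atom count and no clear change in the number. The large steps seen earlier therefore do not follow from any replacement of the diol: a 48-fold lower number from compound 3 to compound 4 (1.68 log units; beyond the scatter) and a 29-fold lower number from compound 2 to compound 4 (1.45 log units; beyond the scatter) set the two ring-bearing amine groups apart from this open chain, and none of the four compounds goes against that split. No measurement shown accounts for either the retained number or the large steps.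

Still open, from the compounds shown here alone, is whether the large steps follow the ring or the amine nitrogen. A (pyrrolidin-1-yl)carbonyl group and an open-chain (2-hydroxyethyl)aminomethyl group would separate the two.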